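Replacing dimethoxymethyl by 2-methoxyethyl on the shared core

A few compounds are considered here, and "the series" means these few. Any claim that something is new, unique, unknown or untested is made for them only; others in the source may bear on it.

Three compounds sharing one core have been examined in an ADME assay on MT4 cells (Homo sapiens) for cytotoxicity, read by MTT assay, with a stated time of 5 days; a higher number here means that more compound is tolerated, a lower number that less compound is tolerated. Compound 1 `Cc1cc(/C=C/C#N)cc(C)c1Oc1cc(NCCN2CCN(C)CC2)nc(Nc2ccc(C#N)cc2)c1` gives 7960 nM in this assay. Compound 2 `Cc1cc(/C=C/C#N)cc(C)c1Oc1cc(NC2CC2)nc(Nc2ccc(C#N)cc2)n1` gives 3000 nM, and compound 3 `COC(Nc1cc(Oc2c(C)cc(/C=C/C#N)cc2C)nc(Nc2ccc(C#N)cc2)n1)OC` gives 3470 nM. Compound 3 thus stands second highest of the three numbers: its nearest neighbour is compound 2, whose number is lower by an amount that stays within the scatter, while compound 1 lies furthest away, with a number beyond the scatter above it.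

Compound 4 `COCCNc1cc(Oc2c(C)cc(/C=C/C#N)cc2C)nc(Nc2ccc(C#N)cc2)n1` has not yet been measured. It differs from compound 3 in one place: 2-methoxyethyl in place of dimethoxymethyl on a nitrogen on an aromatic ring. Among the measured compounds shown here, the only step among the measured compounds that touches the same nitrogen is a 1.2-fold higher number from compound 2 to compound 3 (0.06 log units; within the scatter), and it stayed within the scatter. For the measured compounds named here, no measured pair shows the change from dimethoxymethyl to 2-methoxyethyl itself. The expectation for compound 4 is therefore a step of a 1.1-fold higher number from compound 3 to compound 4 (0.04 log units; within the scatter) in this assay, with no direction clearly favoured. Compound 4 is estimated at 3800 nM, expected to fall between 1700 nM and 8500 nM.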

Compound 4, half-maximal cytotoxic concentration: 3190 nM
The estimate for compound 4 lay 1.2-fold (0.08 log units) above the measured number; the range from low to high includes it.
By their numbers in this assay, from the lowest: compounds 2, 4 and 3 (each within the scatter of the next); then compound 1.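

In this assay, the direct exchange on the nitrogen on an aromatic ring, 2-methoxyethyl in place of dimethoxymethyl, stays within the scatter (a 1.1-fold lower number from compound 3 to compound 4 (0.04 log units; within the scatter)), even though the count falls from 5 heavy atoms to 4 and from 2 hydrogen-bond acceptors to 1. The comparison with cyclopropyl also stays within the scatter (a 1.1-fold higher number from compound 2 to compound 4 (0.03 log units; within the scatter)). Compounds 2, 3 and 4, with one ring and two open chains at this place, therefore cannot be told apart in this assay, a finding that reaches only these three compounds.

As far as these compounds go, what a carboxylic acid or a longer ether chain on this nitrogen would give remains open, as does the effect of a simple amine in that place. Nothing shown here offers an explanation for how closely these numbers lie.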